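Aroyl for aryl on the hydrazide nitrogen: a second instance

The source may report more compounds than this note shows. Statements on the series, on what has been measured and on what is new or still open speak of the compounds shown alone.

Measured compounds:
compound 1, `O=C(NNc1ccccc1Cl)c1cccc(NS(=O)(=O)c2cnc(O)nc2O)c1`, 1460 nM;
compound 2, `O=C(NNc1cccc(Cl)c1)c1ccccc1NS(=O)(=O)c1cnc(O)nc1O`, 5290 nM;
compound 3, `O=C(NNC(=O)c1ccccc1F)c1cccc(NS(=O)(=O)c2cnc(O)nc2O)c1`, 10800 nM.

In a functional assay on A549 cells (Homo sapiens) for antiproliferative activity, read by MTT assay, with a stated time of 24 h (on this read-out lower numbers stand for stronger inhibition and higher numbers for weaker inhibition), compound 2 gives the second highest of the three numbers; compound 3 stands nearest to it, and compound 1, which gives the lowest number, stands furthest from it. Compound 4, `O=C(NNC(=O)c1ccccc1NS(=O)(=O)c1cnc(O)nc1O)c1cccc(Cl)c1`, has not yet been measured. Its difference from compound 2 is (3-chlorophenyl)carbonyl in place of 3-chlorophenyl on an amine nitrogen, that is, the 3-chlorophenyl on the amine nitrogen whose other neighbour is an amide-type nitrogen gives way to a (3-chlorophenyl)carbonyl. Going by the values given here, the one measured step of the same kind is a 7.4-fold higher number from compound 1 to compound 3 (0.87 log units; beyond the scatter), where the ring halogen also changed, so it is only a rough guide. A step in the same direction is therefore expected for compound 4, of a size around that seen from compound 1 to compound 3, which in this assay means a 4.2-fold higher number from compound 2 to compound 4 (0.62 log units; beyond the scatter). The number expected for compound 4 is 22000 nM, within the range 8000 nM to 60000 nM.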

Compound 4, half-maximal inhibitory concentration: 1260 nM
For compound 4 the middle estimate is 17-fold (1.24 log units) above the measured one; measured number below the stated range.
By their numbers in this assay, from the lowest: compounds 4 and 1 (each within the scatter of the next); then compound 2; then compound 3.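

In this assay, placing a carbonyl on the amine nitrogen while keeping the 3-chlorophenyl ring gives a 4.2-fold lower number from compound 2 to compound 4 (0.62 log units; beyond the scatter), so this change is seen here without any change of ring halogen. The earlier step of the same kind ran the other way, with a 7.4-fold higher number from compound 1 to compound 3 (0.87 log units; beyond the scatter), which shows that an aroyl group in place of an aryl group at this position has no fixed direction across the two pairs. Nothing measured here explains the opposite directions.

The two pairs differ in more than one respect, so the compounds shown cannot separate the role of the ring halogen from that of the rest of the core. From the compounds shown here alone, it also remains open how a benzyl group or a (3-methoxyphenyl)carbonyl on the same amine nitrogen would read out on either core.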